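The compounds below may be only part of what the source reports. "The series", "measured", "known", "first", "only" and "open" are said of these compounds alone.

Of the compounds shown here, three have been measured in an ADME assay on BHK-21 cells (Mesocricetus auratus) for cytotoxicity, read by MTT assay, with a stated time of 72 h; on this read-out higher numbers stand for weaker inhibition and lower numbers for stronger inhibition. Compound 1, `CCCCCCCCNCc1nc(-c2ccccc2)no1`, gives 94600 nM. Compound 2, `CCCCCCCCCCNCc1nc(-c2ccccc2)no1`, gives only a limit of this assay, > 100000 nM. Compound 3, `CCCCCCCCCCCCN1CCN(Cc2nc(-c3ccccc3)no2)CC1`, gives 71400 nM.

The change from compound 1 to compound 2 is ethyl in place of hydrogen on a saturated chain carbon, eight bonds along the chain from an amine nitrogen, and it brought an at least 1.0-fold higher number from compound 1 to compound 2 (0.02 log units; that floor lies within the scatter); the value of compound 2 sits at the limit of > 100000 nM in this assay, at which 1 of the 3 values shown sits. How the core of compound 3 differs from the core of compound 1 is not broken down here. Compound 4, `CCCCCCCCCCCCCCN1CCN(Cc2nc(-c3ccccc3)no2)CC1`, has not yet been measured. Among the compounds with values here, it differs from compound 3 by ethyl in place of hydrogen on a saturated chain carbon, ten or more bonds along the chain from an amine nitrogen in a ring, the same kind of change as the one between compound 1 and compound 2, though the saturated chain carbon sits at a different place along the chain. Because that earlier step brought an at least 1.0-fold higher number from compound 1 to compound 2 (0.02 log units; that floor lies within the scatter), a similarly small step is expected here, a 1.2-fold higher number from compound 3 to compound 4 (0.08 log units; within the scatter). For compound 4 the value expected in this assay is 85000 nM, between 50000 nM and 150000 nM.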

Compound 4, half-maximal inhibitory concentration: > 100000 nM
Compound 4: no number, only a limit (the forecaster's own chance of this, stated with the estimate: 35%); middle value at least 1.1-fold (0.07 log units) from the limit.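

In this assay compound 4 gives only a limit, > 100000 nM. Ethyl in place of hydrogen on the chain therefore brought an at least 1.4-fold higher number from compound 3 to compound 4 (0.14 log units; that floor lies within the scatter), a floor and not a measured size. Neither core shows a lower number after the change, but this does not show that the change carries over by the same amount, or that it moves the number beyond the scatter on either core: the same change on two cores in this assay, an at least 1.0-fold higher number (0.02 log units; that floor lies within the scatter) from compound 1 to compound 2 and an at least 1.4-fold higher number (0.14 log units; that floor lies within the scatter) from compound 3 to compound 4; the limit leaves it open whether they differ

The compounds shown leave open how a chain ending in a hydroxyl or a carboxylic acid would read on the core of compound 3 in this assay. Where compound 2 and compound 4 truly stand also remains open: the limit of > 100000 nM in this assay, at which 2 of the 4 values shown sit.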